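This account rests on a few compounds, and the source may have more. Where it says the series, first, only, none or still open, it means among the compounds named here.

Compound 1 `Cc1ccc(NS(=O)(=O)C2CCCCC2=O)c(C)c1`: 0.52%
Compound 2 `Cc1cc(F)ccc1NS(=O)(=O)C1CCCCC1=O`: 3.22%
Compound 3 `O=C1CCCCCC1S(=O)(=O)c1ccc(Cl)c(Cl)c1`: 4.03%

All three compounds were tested in a functional assay on Bel-7402 cells (Homo sapiens) for antiproliferative activity, read by sulforhodamine B assay, tested at 100 ug/mL; a lower number here means less inhibition, a higher number more inhibition at the concentration tested (going by the name of the read-out). On the numbers as they stand, compound 1 sits lowest of the three, yet its gap to compound 2 and its gap to compound 3 are both within the scatter, so the three cannot really be told apart; each shows only a small inhibition at the tested concentration.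

For the measured compounds named here, only one pair of measured compounds differs in a single place. From compound 1 to compound 2 the change is fluoro in place of methyl on an aromatic carbon, and the step is a number 2.7 percentage points higher from compound 1 to compound 2 (within the scatter).

Compound 4 `Cc1ccc(NS(=O)(=O)C2CCCCC2=O)cc1` is the unmeasured compound. It differs from compound 1 as follows: hydrogen in place of methyl on an aromatic carbon. Going by the values given here, the one measured step that bears on this is the exchange at an aromatic carbon from compound 1 to compound 2, which stayed within the scatter. Among the compounds with values here, no measured pair shows a methyl removed altogether, so the evidence is indirect. Since every measured number is small and close together, the expected step is a number 1.5 percentage points higher from compound 1 to compound 4 (within the scatter), no change beyond the scatter. The estimate for compound 4 in this assay is 2%, with a range from 0% to 10%.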

Compound 4, a percentage reported as inhibition, at one concentration (the size of the read-out at that concentration, not a potency): 27.5%
The estimate for compound 4 lay 25.5 percentage points below the measured number, and the stated range ends below it.
By their numbers in this assay, from the lowest: compounds 1, 2 and 3 (each within the scatter of the next); then compound 4.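

In this assay, for the compounds shown here, taking away the methyl that sits ortho to a large group and leaving only hydrogen gives a number 27 percentage points higher from compound 1 to compound 4 (beyond the scatter), the first step in this small set to clear the scatter. The earlier step, a number 2.7 percentage points higher from compound 1 to compound 2 (within the scatter), changed a different aromatic carbon, and compound 2 still carries the methyl that is missing from compound 4, so the two steps show that these two places on the ring do not respond alike to the changes made there. Nothing shown explains why the loss of a single carbon atom at this position goes with more inhibition at the tested concentration.

The compounds shown leave open whether a fluoro, a chloro or a methoxy group at this same position would give a number close to that of the methyl or close to that of the hydrogen. They also leave open what happens when the other methyl, the one meta to this position, is replaced by hydrogen, and when both methyl groups are replaced by hydrogen together.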